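The compounds below may be only part of what the source reports. "The series", "measured", "known", "first", "only" and "open" are said of these compounds alone.

Compound 1 `Fc1ccc(Cl)c(-c2cc(-c3cnn(C4CCNCC4)c3)on2)c1` and compound 2 `Clc1cnccc1-c1cc(-c2cnn(C3CCNCC3)c2)on1` share one core and differ only in the group carried on a single aromatic carbon. In an assay on a protein complex for positive allosteric modulation of Neuronal acetylcholine receptor; alpha4/beta2 (Homo sapiens) (a lower number here means a smaller maximal response, a higher number a larger maximal response), compound 1 gives 29% and compound 2 gives 50%; the change between them is a number 21 percentage points higher from compound 1 to compound 2 (beyond the scatter). For the measured compounds named here, compound 2 therefore stands highest of the two numbers measured so far, with compound 1 as its only neighbour, lower by a margin beyond the scatter.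

Compound 3 `c1nn(C2CCNCC2)cc1-c1cc(C2CCCCC2)no1` is not yet measured. It differs from compound 2 by cyclohexyl in place of 3-chloropyridin-4-yl on an aromatic carbon. Going by the values given here, the one measured step at this position, a number 21 percentage points higher from compound 1 to compound 2 (beyond the scatter), shows that exchanging the group on this aromatic carbon can move the maximal response by a modest amount. That step, however, exchanged one six-membered aromatic ring for another, whereas here an aromatic ring gives way to a six-membered non-aromatic ring of carbon only. Among the compounds with values here, no measured step covers a change of that kind, so the direction is open: a modest step either way, or none beyond the scatter, is conceivable. The expected step is taken as a number 12 percentage points lower from compound 2 to compound 3 (beyond the scatter), a small lowering. Compound 3 is estimated to give 38%, within a range of 18% to 60%.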

Compound 3, largest response reached (reported as efficacy), in percent of the reference or control that the assay uses: 16%
Compound 3: the middle estimate sits 22 percentage points above what was measured; measured number below the stated range.
By their numbers in this assay, from the lowest: compound 3; then compound 1; then compound 2.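

In this assay, both steps from an aromatic group to cyclohexyl on this carbon, next to the ring nitrogen, go the same way: the replacement of 3-chloropyridin-4-yl gives a large lowering (a number 34 percentage points lower from compound 2 to compound 3 (beyond the scatter)), and the replacement of 2-chloro-5-fluorophenyl gives a modest one (a number 13 percentage points lower from compound 1 to compound 3 (beyond the scatter)). The earlier step showed only an exchange between two six-membered aromatic rings, whereas these steps show that a six-membered non-aromatic ring of carbon only gives the lowest number of the three, from either aromatic starting point. Nothing measured alongside these numbers accounts for the lowering.

The step from compound 2 to compound 3 removes the aromatic ring, the ring nitrogen and the chlorine together, so these three compounds cannot show which of those changes carries the loss. From the compounds shown here alone, whether an unsubstituted phenyl would hold the number nearer that of the two aromatic groups, and whether a cyclohexyl bearing an amine would recover any of the lost response, remains open.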